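Inverting the ring configuration on the methoxycyclohexyl compound

The source may hold more compounds than are shown below. What is called first, only, known or untested is meant among the compounds shown, and "the series" means these compounds.

The measured compounds:
Compound 1 `Nc1ncnc2c1c(Oc1cc(C(F)(F)F)ccn1)nn2C1CC1` gives > 2.41 h in an ADME assay on microsomes from liver (Homo sapiens) for metabolic stability, read by LC-MS, using NADPH, with a stated time of 10 min, tested at 10 uM; a lower number here means that the compound disappears faster, a higher number that the compound lasts longer; this is a limit of the assay.
Compound 2 `Nc1ncnc2c1c(Oc1cc(C(F)(F)F)ccn1)nn2[C@H]1CC[C@@H](N)CC1` gives > 2.41 h in this assay; this is a limit of the assay.
Compound 3 `CO[C@H]1CC[C@@H](n2nc(Oc3cc(C(F)(F)F)ccn3)c3c(N)ncnc32)CC1` gives 0.317 h in this assay.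

Compound 3 is the only one of the three with an actual number; the other two sit at a limit of the assay, (the limit of > 2.41 h in this assay, at which 2 of the 3 values shown sit). The step of an at least 7.6-fold lower number from compound 1 to compound 3 (0.88 log units; beyond the scatter) and the step of an at least 7.6-fold lower number from compound 2 to compound 3 (0.88 log units; beyond the scatter) both end on compound 3, so it stands clearly lower than the two limits allow for compound 1 and compound 2.

Compound 4 `CO[C@H]1CC[C@H](n2nc(Oc3cc(C(F)(F)F)ccn3)c3c(N)ncnc32)CC1` is the next compound. Relative to compound 3, (the two compounds have the same atoms and bonds and differ only in configuration as drawn: 2 of 2 stereo elements differ (all stereocentres are inverted: mirror images); a stereocentre at a saturated ring carbon is drawn s in compound 3 and r in compound 4; a stereocentre at a saturated ring carbon is drawn s in compound 3 and r in compound 4). For the measured compounds named here, none of the measured steps changes only configuration; each of them exchanges one group for another, so no measured step speaks directly to this change. The one comparison that concerns compound 3 itself places it far below the limits, and nothing shown says that flipping the drawn configuration moves a compound out of that range.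

Compound 4 is therefore expected to stay close to compound 3, with a step of a 1.3-fold higher number from compound 3 to compound 4 (0.10 log units; within the scatter). The estimate for compound 4 in this assay is 0.4 h, between 0.15 h and 1.2 h.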

Compound 4, half-life: > 2.41 h
Compound 4 gave a limit, no number; the forecaster's own chance of this, stated with the estimate: 10%; at least 6.0-fold (0.77 log units) between middle value and limit.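

In this assay the configuration of the ring matters as much as the group on it, with an at least 7.6-fold higher number from compound 3 to compound 4 (0.88 log units; beyond the scatter). The short half-life of compound 3 therefore cannot be put down to the methoxy group or the cyclohexyl ring alone, because the two compounds carry the same atoms and bonds, and the large gap rests on a single point: the fact that compounds 3 and 4 differ only in the configuration as drawn. Compound 4 gives a limit of the assay and not a number, so its steps from compound 1 and compound 2 cannot be read, and the top of the range remains crowded: the limit of > 2.41 h in this assay, at which 3 of the 4 values shown sit.

The compounds shown leave open how far beyond the limit compound 4 really lies, and so the true size of the gap, as well as whether inverting the ring of compound 2 would change its half-life in the same way. They also leave open whether a hydroxyl or an ethoxy group on the same saturated ring carbon would show the same split between the two configurations.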